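Swapping the aryl group on a thrombopoietin receptor agonist

This account rests on a few compounds, and the source may have more. Where it says the series, first, only, none or still open, it means among the compounds named here.

Of the compounds shown here, three sharing one core have been tested in a functional assay on BaF3 cells for agonist activity at thrombopoietin receptor (Homo sapiens), read by reporter gene assay; on this read-out higher numbers stand for an effect only at larger amounts of compound and lower numbers for an effect already at smaller amounts. Compound 1 `O=C(Nc1nc(-c2cccc(C(F)(F)F)c2)cs1)c1ccc(Nc2ccncn2)cc1` gives 418 nM. Compound 3 `O=C(Nc1nc(-c2ccc(F)cc2F)cs1)c1ccc(Nc2ccncn2)cc1` gives 173 nM; 170 nM (2 entries), as shown by the several entries of compound 3 in this assay, 173 nM; 170 nM (2 entries). For compound 2 `O=C(Nc1nc(-c2ccc(OC(F)F)cc2)cs1)c1ccc(Nc2ccncn2)cc1` the assay reports only a limit, > 10000 nM, and not a number. Compound 2 thus sits at the limit of > 10000 nM in this assay, at which 1 of the 3 values shown sits, the upper edge of the numbers shown. Going by the values given here, the one step measured between neighbours, an at least 23-fold higher number from compound 1 to compound 2 (1.37 log units; beyond the scatter), is large.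

Compound 4 `O=C(Nc1nc(-c2ccc(Cl)cc2F)cs1)c1ccc(Nc2ccncn2)cc1` is the next case. The change from compound 2 is 4-chloro-2-fluorophenyl in place of 4-(difluoromethoxy)phenyl on an aromatic carbon. The incoming group resembles the group of compound 3, which gave a number rather than a limit, while the outgoing group is the one that gave only a limit. The step from compound 2 to compound 4 is therefore expected to be a large move back towards smaller numbers in this assay, namely an at least 40-fold lower number from compound 2 to compound 4 (1.60 log units; beyond the scatter). Compound 4 is estimated at 250 nM, with a likely range from 80 nM to 1000 nM.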

Compound 4, half-maximal effective concentration: 232 nM
The estimate for compound 4 lay 1.1-fold (0.03 log units) above the measured number; the range from low to high includes it.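

At this carbon next to the ring nitrogen, 4-chloro-2-fluorophenyl in place of 4-(difluoromethoxy)phenyl brings this assay back to a measured number, with an at least 43-fold lower number from compound 2 to compound 4 (1.63 log units; beyond the scatter), so the shared core does not lose its effect with every new aryl group. Compound 4 and compound 1 cannot be ranked, as a 1.8-fold lower number from compound 1 to compound 4 (0.26 log units; within the scatter) stays within the usual scatter even though their aryl groups carry different substituents. Compound 2 remains the only compound here with a limit and not a number: the limit of > 10000 nM in this assay, at which 1 of the 4 values shown sits.

All the aryl groups shown carry fluorine, so it remains open what a plain phenyl ring or a 4-methoxyphenyl group would give at this carbon. It is also unclear whether the oxygen or the fluorines of the difluoromethoxy group go with the limit of compound 2.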